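A few compounds are considered here, and "the series" means these few. Any claim that something is new, unique, unknown or untested is made for them only; others in the source may bear on it.

Compound 1 `CN1C(=O)[C@@]2(c3ccccc31)N(C)C[C@@H](c1ccco1)[C@@]21Cc2ccccc2C1=O` is the lower of two measured numbers in a functional assay on the whole organism (strain Wister albino) for inhibition, with Rattus norvegicus as the target, read by paw edema, with stated times of 1 h and 4 h, at a dose of 50 mg/kg by the intraperitoneal route (on this read-out higher numbers stand for more inhibition at the one dose given (going by the name of the read-out) and lower numbers for less inhibition), where compound 1 gives 8.2%. Compound 2 `CN1C(=O)[C@@]2(c3ccccc31)N(C)C[C@@H](c1ccc(Cl)cc1)[C@@]21Cc2ccccc2C1=O`, in this assay, gives 8.5%, and the change a number 0.3 percentage points higher from compound 1 to compound 2 (within the scatter) lies within the scatter. Compound 3 `CN1C[C@@H](c2ccco2)[C@@]2(Cc3ccccc3C2=O)[C@@]12C(=O)Nc1ccccc12` differs from compound 1 by hydrogen in place of methyl on an amide-type nitrogen in a ring. No measured step touches an amide-type nitrogen in a ring, so nothing shown bears directly on this change; the one step known was small. A change of a number 0.8 percentage points higher from compound 1 to compound 3 (within the scatter) is therefore expected, none beyond the scatter. Compound 3 is estimated at 9%, in a range from 0% to 20%.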

Compound 3, a percentage reported as inhibition, in the whole organism at one dose (the size of the read-out at that dose, not a potency): 33.5%
Beside the measured number, compound 3's estimate is 24.5 percentage points below it, and the stated range ends below it.
By their numbers in this assay, from the lowest: compounds 1 and 2 (each within the scatter of the next); then compound 3.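

At the amide-type nitrogen in a ring, hydrogen in place of methyl is the first single change shown to move the number in this assay beyond the scatter, with a number 25.3 percentage points higher from compound 1 to compound 3 (beyond the scatter) as the step. The other step shown, a number 0.3 percentage points higher from compound 1 to compound 2 (within the scatter), on a saturated ring carbon, stayed within it. No measurement shown accounts for the gain at this nitrogen.

From the compounds shown here alone, whether ethyl or acetyl on that nitrogen would give a number nearer that of the methyl or of the hydrogen remains open. So does whether the same change would give a similar step with 4-chlorophenyl in place of furan-2-yl.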